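This account rests on a few compounds, and the source may have more. Where it says the series, first, only, none or still open, it means among the compounds named here.

Measured in an ADME assay on MT4 cells (Homo sapiens) for cytotoxicity, read by MTT assay; a higher number here means that more compound is tolerated, a lower number that less compound is tolerated:
- compound 1 `Cc1ccc(CC2C(=O)N(O)C(=O)c3ccccc32)cc1`: 5500 nM
- compound 2 `CCCCCCC1C(=O)N(O)C(=O)c2ccccc21`: 4400 nM

Within the data shown here, compound 2 stands within the scatter of compound 1, the only other measured compound. Compound 3 `CCCC1C(=O)N(O)C(=O)c2ccccc21` follows from compound 2 by hydrogen in place of propyl on a saturated chain carbon, three bonds along the chain from a saturated ring carbon, in words hydrogen in place of propyl on a saturated chain carbon, three bonds along the chain from a saturated ring carbon, so hexyl becomes propyl.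

Among the measured compounds shown here, one measured step bears on this, pentyl in place of 4-methylphenyl: a 1.3-fold lower number from compound 1 to compound 2 (0.10 log units; within the scatter). For the measured compounds named here, no measured step shortens a chain, so the guide is weak, and no step beyond the scatter is expected in this assay. The expected change is a 1.3-fold higher number from compound 2 to compound 3 (0.10 log units; within the scatter). For compound 3 the estimated value is 5500 nM, with an expected range of 2800 nM to 13000 nM.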

Compound 3, half-maximal cytotoxic concentration: 25400 nM
The estimate for compound 3 lay 4.6-fold (0.66 log units) below the measured number, outside the stated range (above it).
By their numbers in this assay, from the lowest: compounds 2 and 1 (each within the scatter of the next); then compound 3.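

In this assay this position responds to the chain on it, which the earlier pair did not show: hexyl to propyl gives a 5.8-fold higher number from compound 2 to compound 3 (0.76 log units; beyond the scatter) and the tolerated concentration rises. Ethyl in place of 4-methylphenyl at the same place gives a 4.6-fold higher number from compound 1 to compound 3 (0.66 log units; beyond the scatter), so compound 3 stands apart from both compound 1 and compound 2, which remain within the scatter of each other. No available data explain this rise.

Whether the number climbs gradually or abruptly between propyl and hexyl remains open, with butyl and pentyl chains absent from the compounds shown. From the compounds shown here alone, how an amine or a carboxylic acid would read at this position is also open.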